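From Chloro to 4-Fluorophenyl on a Sulfonamide Arene

A few compounds are considered here, and "the series" means these few. Any claim that something is new, unique, unknown or untested is made for them only; others in the source may bear on it.

Compound 1 `CC1CCN(C2CCN(S(=O)(=O)c3cccc(C(F)(F)F)c3)CC2)CC1` gives > 5000 nM in a functional assay on DLD-1 cells (Homo sapiens) for antiproliferative activity, read by CellTiter-Glo, with a stated time of 72 h; a lower number here means a stronger inhibitor, a higher number a weaker inhibitor.
Compound 2 `CC1CCN(C2CCN(S(=O)(=O)c3cccc(Cl)c3)CC2)CC1` gives > 5000 nM in this assay.

The value for compound 1 is a limit of the assay, not a number. The value for compound 2 is likewise a limit. Between the two lies a step that the two limits leave unreadable from compound 1 to compound 2, which stays unreadable because of the limit of > 5000 nM in this assay, at which 2 of the 2 values shown sit. Compound 2 therefore stands only at that limit; nothing shown places it more precisely.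

Compound 3 `CC1CCN(C2CCN(S(=O)(=O)c3cccc(-c4ccc(F)cc4)c3)CC2)CC1` differs from compound 2 by 4-fluorophenyl in place of chloro on an aromatic carbon. Going by the values given here, the single measured step exchanges one small group for another and left nothing readable, so it gives no guide to a change that brings in a whole aromatic ring. Among the compounds with values here, no measured step bears on this change.

With both measured compounds at the limit, compound 3 is expected to give about 5000 nM, within 1000 nM to 20000 nM, most likely again as a limit. The step expected here is a number no higher from compound 2 to compound 3 (the limit leaves the size open), not beyond the scatter.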

Compound 3, half-maximal inhibitory concentration: 12 nM
Beside the measured number, compound 3's estimate is 420-fold (2.62 log units) above it; measured number below the stated range.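

In this assay, this aromatic carbon proves able to carry a large change in the read-out: 4-fluorophenyl in place of chloro gives an at least 410-fold lower number from compound 2 to compound 3 (2.61 log units; beyond the scatter), and 4-fluorophenyl in place of trifluoromethyl gives an at least 410-fold lower number from compound 1 to compound 3 (2.61 log units; beyond the scatter). Of the three compounds, only compound 3 gives a readable number, 12 nM, so a group bringing in a whole aromatic ring at this carbon achieves what neither chloro nor trifluoromethyl showed. Both steps are minimum sizes, and their true sizes stay unknown: the limit of > 5000 nM in this assay, at which 2 of the 3 values shown sit.

The compounds shown cannot separate the contribution of the added ring from that of its fluorine, as plain phenyl is not among them. From the compounds shown here alone, how a pyridine ring, or a phenyl ring carrying an amine or a carboxylic acid, would behave at this carbon also remains open.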